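Butyl to ethoxymethyl on the triazole of compound 2

The source may report more compounds than this note shows. Statements on the series, on what has been measured and on what is new or still open speak of the compounds shown alone.

Measured so far:
compound 1 `CCCCc1cn(-c2ccc(NC(=O)Nc3ccccc3C)cc2)nn1` — 300 nM
compound 2 `CCCCc1cn(-c2cccc(S(=O)(=O)Nc3ccccc3C(F)(F)F)c2)nn1` — 400 nM

In an assay for inhibition of ATP-dependent RNA helicase DDX3X (Homo sapiens), read by FRET, with a stated time of 40 min, in the presence of a further agent that is not named here (a higher number here means a weaker inhibitor, a lower number a stronger inhibitor), compound 1 gives 300 nM. In this assay compound 2 gives 400 nM. Of the two numbers, compound 2 carries the higher one, but its gap to compound 1 lies within the scatter of repeated measurements, so the two compounds read as equivalent on this assay; they differ in more than one place, so nothing is learned about any single change from them.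

Compound 3 `CCOCc1cn(-c2cccc(S(=O)(=O)Nc3ccccc3C(F)(F)F)c2)nn1` is not yet measured. It differs from compound 2 in one place: ethoxy in place of propyl on a saturated chain carbon bound to an aromatic carbon. Among the measured compounds shown here, no step between measured compounds speaks to this change, and the two values in hand give no direction for it. The change keeps the chain length on the shared core and only swaps one chain member, so the expected step from compound 2 to compound 3 in this assay is a 1.5-fold higher number from compound 2 to compound 3 (0.18 log units; within the scatter), a step not clearly beyond the scatter, with a small lean toward a higher number. Compound 3 is therefore expected to give 600 nM, within a range of 200 nM to 1800 nM.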

Compound 3, half-maximal inhibitory concentration: 400 nM
Estimate against measurement, compound 3: 1.5-fold (0.18 log units) above; low and high end bracket the measured number.
By their numbers in this assay, from the lowest: compounds 1, 2 and 3 (each within the scatter of the next).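

In this assay, among the compounds shown here, the reading is no change at the digits printed from compound 2 to compound 3 (within the scatter), and this is the first comparison that isolates a single place. On this one pair, swapping propyl for ethoxy gives no step beyond the scatter, although the entering group carries 1 hydrogen-bond acceptor and the leaving group carries none, at an unchanged count of 3 heavy atoms. No measurement in hand speaks to the reason for this result.

Open, going by these compounds, is how far this position accepts other groups: an amine, a carboxylic acid or a longer chain such as hexyl in place of ethoxy would show whether the reading in this assay holds with a larger substituent, and the present pair gives no direction for any of them. Also open, on these data alone, is whether butyl to ethoxymethyl reads the same way on the core of compound 1, which so far is known only with butyl on the triazole.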